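From Pyrrolidin-1-yl to (Dimethylamino)methyl

The source may hold more compounds than are shown below. What is called first, only, known or untested is meant among the compounds shown, and "the series" means these compounds.

In a functional assay on HL-60 cells (Homo sapiens) for antiproliferative activity, read by MTT assay, with a stated time of 48 h (a higher number here means a weaker inhibitor, a lower number a stronger inhibitor), compound 1 (`Cn1c(N)c(-c2nc3ccccc3[nH]2)c2nc(C#N)c(C#N)nc21`) reads > 50000 nM as a limit of the assay. Compound 2 (`CCn1c(N)c(-c2nc3ccccc3[nH]2)c2nc(C#N)c(C#N)nc21`) reads > 50000 nM as a limit too. Within the data shown here, compound 3 (`N#Cc1nc2c(-c3nc4ccccc4[nH]3)c(N)n(CCN3CCCC3)c2nc1C#N`) gives 4760 nM as the only actual number of the three. Compound 4 (`CN(C)CCCn1c(N)c(-c2nc3ccccc3[nH]2)c2nc(C#N)c(C#N)nc21`) differs from it by (dimethylamino)methyl in place of pyrrolidin-1-yl on a saturated chain carbon, two bonds along the chain from an aromatic nitrogen with (dimethylamino)methyl in place of pyrrolidin-1-yl on a saturated chain carbon. Among the measured compounds shown here, two measured steps bear on this: an at least 10-fold lower number from compound 1 to compound 3 (1.02 log units; beyond the scatter) and an at least 10-fold lower number from compound 2 to compound 3 (1.02 log units; beyond the scatter) are both large, and each brought in the pyrrolidin-1-yl end, though neither tests the exchange itself. Compound 4 is therefore expected to stay close to compound 3 rather than fall back to the limit. The expected change is a 1.2-fold lower number from compound 3 to compound 4 (0.08 log units; within the scatter) and so none beyond the scatter. Compound 4 is estimated at 4000 nM with an expected range from 1200 nM to 15000 nM in this assay overall.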

Compound 4, half-maximal inhibitory concentration: 870 nM
Compound 4: middle estimate off by 4.6-fold (0.66 log units), on the high side; the whole stated range lies above it.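

In this assay, among these compounds, the exchange itself, untested by the earlier steps, proves to matter at this place: it gives a 5.5-fold lower number from compound 3 to compound 4 (0.74 log units; beyond the scatter). Against the plain chains, the new end gives an at least 57-fold lower number from compound 2 to compound 4 (1.75 log units; beyond the scatter) and an at least 57-fold lower number from compound 1 to compound 4 (1.75 log units; beyond the scatter). Both of these steps start from a limit of the assay, so their full size cannot be read: the limit of > 50000 nM in this assay, at which 2 of the 4 values shown sit.

As far as these compounds go, the length of the chain and the amine change together in this exchange, and the share of each stays open. A 3-(pyrrolidin-1-yl)propyl chain on the aromatic nitrogen would separate the two.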